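The source may report more compounds than this note shows. Statements on the series, on what has been measured and on what is new or still open speak of the compounds shown alone.

Working notes on the series. Compound 2 `O=C1CCCN1c1cnc(NCc2c(F)ccc3c2CCO3)c2cn[nH]c(=O)c12` carries a 2-oxopyrrolidin-1-yl group on the aromatic carbon in question. In a physicochemical assay for solubility, read by LC-MS, in phosphate buffer, with a stated time of 24 h, at pH 7.4 (on this read-out lower numbers stand for lower solubility and higher numbers for higher solubility), compound 2 gives < 2000 nM, which is a limit of the assay and not a number (the limit of < 2000 nM in this assay, at which 1 of the 2 values shown sits). Among the compounds with values here, compound 1 `CNC(=O)c1cc(-c2cnc(NCc3c(F)ccc4c3CCO4)c3cn[nH]c(=O)c23)n(C)n1` gives 7000 nM in this assay, and the only measured step, an at least 3.5-fold lower number from compound 1 to compound 2 (0.54 log units; beyond the scatter), runs from an aromatic substituent bearing a methylcarbamoyl group to the non-aromatic lactam. Compound 3 `Cc1nc(CO)ccc1-c1cnc(NCc2c(F)ccc3c2CCO3)c2cn[nH]c(=O)c12` is not yet measured; the change from compound 2 is 6-(hydroxymethyl)-2-methylpyridin-3-yl in place of 2-oxopyrrolidin-1-yl on an aromatic carbon. Within the data shown here, the one measured step bears on it only in reverse: the entering group is again an aromatic ring with a hydrogen-bond donor, as in compound 1, so a return toward the region of compound 1 is expected rather than a further fall. Compound 3 is therefore expected to give 4500 nM in this assay, with a range from 1500 nM to 13000 nM. This estimate means an expected step of an at least 2.2-fold higher number from compound 2 to compound 3 (0.35 log units; beyond the scatter), which would be beyond the scatter if it holds, though the lower end stays near the limit.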

Compound 3, solubility: 3000 nM
For compound 3 the middle estimate is 1.5-fold (0.18 log units) above the measured one, and the stated range covers the measured number.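

At this aromatic carbon, 6-(hydroxymethyl)-2-methylpyridin-3-yl in place of 1-methyl-3-(methylcarbamoyl)-1H-pyrazol-5-yl gives a 2.3-fold lower number from compound 1 to compound 3 (0.37 log units; beyond the scatter), so in this assay two aromatic substituents that both carry a hydrogen-bond donor do not read alike, and the position responds to more than the presence of such a ring. Against the non-aromatic lactam, the same group gives an at least 1.5-fold higher number from compound 2 to compound 3 (0.17 log units; that floor lies within the scatter), so the result does not establish a rise over the 2-oxopyrrolidin-1-yl group, and the true size of this step remains unknown. The value of compound 2 is a limit of the assay and not a number: the limit of < 2000 nM in this assay, at which 1 of the 3 values shown sits.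

The compounds shown do not separate the share of the hydroxymethyl group from that of the 2-methyl group or of the ring itself in the difference from compound 1. Going by these compounds, how an aminomethyl group or a carboxylic acid in place of the hydroxymethyl group would read in this assay also remains open, as does any effect of a longer chain at that site.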